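The source may report more compounds than this note shows. Statements on the series, on what has been measured and on what is new or still open speak of the compounds shown alone.

Measured so far in an ADME assay on MT4 cells (Homo sapiens) for cytotoxicity, read by MTT assay; a higher number here means that more compound is tolerated, a lower number that less compound is tolerated:
- compound 1 `Cc1ccccc1C(=O)N(C(=S)OCCN1C(=O)c2ccccc2C1=O)c1ccc(Cl)cc1` gives 21000 nM
- compound 2 `O=C1c2ccccc2C(=O)N1CCOC(=S)N(C(=O)c1cc(F)cc(F)c1)c1ccc(Cl)cc1` gives 59000 nM
- compound 3 `O=C1c2ccccc2C(=O)N1CCOC(=S)N(C(=O)c1c(Cl)cccc1Cl)c1ccc(Cl)cc1` gives 20000 nM

Compound 3 sits at the low end of these numbers, level with compound 1 (a step of a 1.1-fold lower number from compound 1 to compound 3 (0.02 log units; within the scatter)). The remaining compound lies clearly higher (a step of a 3.0-fold lower number from compound 2 to compound 3 (0.47 log units; beyond the scatter)).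

The next compound is compound 4 `O=C1c2ccccc2C(=O)N1CCOC(=S)N(C(=O)c1cc(Cl)cc(Cl)c1)c1ccc(Cl)cc1`, which differs from compound 3 in one place (3,5-dichlorophenyl in place of 2,6-dichlorophenyl on a carbonyl carbon). It has 3,5-dichlorophenyl in place of 2,6-dichlorophenyl on a carbonyl carbon.

The closest guide is compound 2, whose 3,5-difluorophenyl carries the same numbering, with fluorine instead of chlorine. Its step to the 2,6-dichlorophenyl compound was modest (a 3.0-fold lower number from compound 2 to compound 3 (0.47 log units; beyond the scatter)), and so was its step from the 2-methylphenyl compound (a 2.8-fold higher number from compound 1 to compound 2 (0.45 log units; beyond the scatter)). Within the data shown here, no measured pair shows fluorine swapped for chlorine, so only part of that size is expected to carry over. The expected change in this assay is therefore a modest rise (a 2.1-fold higher number from compound 3 to compound 4 (0.32 log units; beyond the scatter)). As an estimate, compound 4 is expected at 42000 nM (expected range 18000 nM to 90000 nM).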

Compound 4, half-maximal cytotoxic concentration: 32000 nM
Estimate against measurement, compound 4: 1.3-fold (0.12 log units) above; the range from low to high includes it.
By their numbers in this assay, from the lowest: compounds 3, 1, 4 and 2 (each within the scatter of the next, the first and the last beyond it).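

In this assay the two chlorines can be rearranged, with 3,5-dichlorophenyl in place of 2,6-dichlorophenyl on the carbonyl carbon, without a change that stands clear of the scatter (a 1.6-fold higher number from compound 3 to compound 4 (0.20 log units; within the scatter)). Among these compounds, this is also the first direct look at chlorine in place of fluorine in a 3,5-disubstituted phenyl (a 1.8-fold lower number from compound 2 to compound 4 (0.27 log units; within the scatter)), and compound 4 likewise cannot be separated from the 2-methylphenyl compound (a 1.5-fold higher number from compound 1 to compound 4 (0.18 log units; within the scatter)), so it bridges compounds 2 and 3, which do differ beyond the scatter. No measurement shown here explains these numbers.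

All groups shown at this position are phenyl rings bearing methyl, fluorine or chlorine. Going by these compounds, whether a carboxylic acid or an amine on that ring, or a longer chain in its place, would move the number clearly remains open.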